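The source may report more compounds than this note shows. Statements on the series, on what has been measured and on what is new or still open speak of the compounds shown alone.

In an ADME assay on MT4 cells (Homo sapiens) for cytotoxicity (on this read-out lower numbers stand for higher toxicity in this test and higher numbers for lower toxicity in this test), compound 1 (`CCCC[C@H]1CC[C@H](c2ccc(NC(=S)Nc3cccc(C(F)(F)F)c3)cc2)CC1`) gives (22000 nM), compound 2 (`Fc1ccc(NC(=S)Nc2cccc(C(F)(F)F)c2)cc1Cl`) gives (8000 nM) and compound 3 (`Fc1ccc(NC(=S)Nc2cccc(C(F)(F)F)c2)cc1`) gives (31000 nM). Compound 3 is on a par with compound 1 and has the higher number against compound 2. Compound 4 (`FC(F)(F)c1cccc(NC(=S)NCc2ccco2)c1`) carries (furan-2-yl)methyl in place of 4-fluorophenyl on an amide-type nitrogen. Both measured steps alter only substituents on the aromatic ring that leaves here, so they bear on this change only indirectly: one is small (a 1.4-fold higher number from compound 1 to compound 3 (0.15 log units; within the scatter)) and the other modest (a 3.9-fold higher number from compound 2 to compound 3 (0.59 log units; beyond the scatter)). No step beyond the scatter is therefore expected in this assay. The expected step is small (a 1.3-fold higher number from compound 3 to compound 4 (0.11 log units; within the scatter)). For compound 4 the estimated value is 40000 nM (range 15000 nM to 100000 nM).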

Compound 4, half-maximal cytotoxic concentration: 43000 nM
For compound 4 the middle estimate is 1.1-fold (0.03 log units) below the measured one; measured number inside the range.
By their numbers in this assay, from the lowest: compound 2; then compounds 1, 3 and 4 (each within the scatter of the next).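

Replacing the whole 4-fluorophenyl on the amide-type nitrogen with (furan-2-yl)methyl gives a 1.4-fold higher number from compound 3 to compound 4 (0.14 log units; within the scatter) in this assay. The earlier steps shown here changed only substituents on that aromatic ring, whereas this one shows that the ring itself can be exchanged, with a methylene-linked five-membered aromatic ring, without a step beyond the scatter. Nothing available explains the result at this position.

Still open, from the compounds shown here alone, is whether a benzyl group would read the same as (furan-2-yl)methyl. Also open, going by these compounds, is how a carboxylic acid or an aliphatic amine on this nitrogen would read.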